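The source may hold more compounds than are shown below. What is called first, only, known or untested is meant among the compounds shown, and "the series" means these compounds.

The study follows four compounds in an assay on membranes from liver for displacement of a labelled ligand from Sigma intracellular receptor 2 (Rattus norvegicus), read by scintillation counting, with a stated time of 120 min; a higher number here means a weaker inhibitor, a lower number a stronger inhibitor. Compound 1 `CN(CCCCc1ccccc1)C1CCc2ccccc2C(O)C1` gives 66 nM, and compound 2 `CN(CCCc1ccccc1)C1CCc2ccccc2C(O)C1` gives 35 nM. Compound 3 `OC1Cc2ccccc2CCC1NCCCc1ccccc1` rests on a different core; the difference between the two cores is not broken down here. In this assay compound 3 gives 100 nM. Compound 4 `OC1Cc2ccccc2CCC1NCCCCc1ccccc1` has not yet been measured.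

The change from compound 2 to compound 1 is benzyl in place of phenyl on a saturated chain carbon, three bonds along the chain from an amine nitrogen, and it produced a 1.9-fold higher number from compound 2 to compound 1 (0.28 log units; within the scatter). The change from compound 3 to compound 4 is benzyl in place of phenyl on a saturated chain carbon, three bonds along the chain from an amine nitrogen, the same change at the same place. Because that earlier change gave a 1.9-fold higher number from compound 2 to compound 1 (0.28 log units; within the scatter), the step expected here is a 1.8-fold higher number from compound 3 to compound 4 (0.26 log units; within the scatter). Compound 4 is accordingly estimated at 180 nM, with a range from 80 nM to 400 nM.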

Compound 4, inhibition constant: 100 nM
Compound 4: the middle estimate sits 1.8-fold (0.26 log units) above what was measured; measured number inside the range.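

In this assay, benzyl in place of phenyl on a saturated chain carbon, three bonds along the chain from an amine nitrogen, gives no change at the digits printed from compound 3 to compound 4 (within the scatter). The step on this core agrees with the step on the core of compound 1: the same change on two cores in this assay, a 1.9-fold higher number (0.28 log units; within the scatter) from compound 2 to compound 1 and no change at the digits printed (within the scatter) from compound 3 to compound 4, 1.9-fold (0.28 log units) apart, within the scatter of two such steps In this one assay, the change therefore carries from one core to the other without a detectable difference, but since each step lies within the scatter, this does not show that the change has a real effect on either core.

The compounds shown leave open whether a longer chain would give a step beyond the scatter. They also leave open what a carboxylic acid in place of the phenyl would do.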